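Polyacetylenic Hydroxy Acids: Alkyne to Alkene at the Hydroxylated End

The source may report more compounds than this note shows. Statements on the series, on what has been measured and on what is new or still open speak of the compounds shown alone.

compound 1 `O=C(O)CCCCCCCC#CC#CC#CC#C[C@@H](O)CO`: 14.6 ug/mL
compound 2 `C[C@H](O)C#CC#CC#CC#CCCCCCCCC(=O)O`: 4.1 ug/mL

In a functional assay on Lu1 cells (Homo sapiens) for cytotoxicity (on this read-out lower numbers stand for an effect already at smaller amounts and higher numbers for an effect only at larger amounts of compound), compound 1 gives 14.6 ug/mL, while compound 2 gives 4.1 ug/mL, the lower of the two numbers. Going by the values given here, the one measured step, a 3.6-fold lower number from compound 1 to compound 2 (0.55 log units; beyond the scatter), concerns hydrogen in place of hydroxy and leaves the triple bonds untouched. Compound 3 `C[C@H](O)/C=C/C#CC#CC#CCCCCCCCC(=O)O` carries 3-hydroxybut-1-en-1-yl in place of 3-hydroxybut-1-yn-1-yl on a triple-bonded carbon. Among the compounds with values here, no measured step bears on a triple bond becoming a double bond, so in this assay the expected step is a 1.2-fold higher number from compound 2 to compound 3 (0.09 log units; within the scatter), nothing beyond the scatter. For compound 3 the estimate in this assay is 5 ug/mL, within 2 ug/mL to 12 ug/mL.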

Compound 3, concentration for half-maximal effect: > 20 ug/mL
Compound 3 ended at the assay's limit (the forecaster's own chance of this, stated with the estimate: 5%); middle value at least 4.0-fold (0.60 log units) from the limit.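

In this assay the value of compound 3 is a limit of the assay, not a number: the limit of > 20 ug/mL in this assay, at which 1 of the 3 values shown sits. Replacing 3-hydroxybut-1-yn-1-yl with 3-hydroxybut-1-en-1-yl on a triple-bonded carbon gives an at least 4.8-fold higher number from compound 2 to compound 3 (0.68 log units; beyond the scatter), so this end of the chain responds to the triple bond itself, which the hydroxy-to-hydrogen step could not show. The comparison with the dihydroxy end gives an at least 1.3-fold higher number from compound 1 to compound 3 (0.13 log units; that floor lies within the scatter), a floor that separates neither compound from the other.

On these data alone, the true size of the step from the triple bond stays open. So does how an amine in place of the hydroxy, or a longer chain at this end, would read.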